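The source may hold more compounds than are shown below. What is called first, only, known or untested is meant among the compounds shown, and "the series" means these compounds.

Measured so far in a toxicity assay on NIH3T3 cells (Mus musculus) for cytotoxicity, read by resazurin assay; a lower number here means that less compound is needed, a higher number that more compound is needed for the effect:
compound 1 `COC(=O)c1ccc(NCc2cncn2Cc2ccc(C#N)cc2)cc1-c1ccccc1` gives > 10000 nM
compound 2 `c1ccc(-c2ccc(Cn3cncc3CNc3ccccc3-c3ccccc3)cc2)cc1` gives > 10000 nM
compound 3 `CCc1ccc(Cn2cncc2CNc2ccc(-c3nc4ccccc4s3)c(-c3ccccc3)c2)cc1` gives > 1000 nM

None of the three readings is a number; each is a limit of the assay. Compound 3 stands at the limit of > 1000 nM in this assay, at which 1 of the 3 values shown sits. Compound 1 stands at the limit of > 10000 nM in this assay, at which 2 of the 3 values shown sit. Compound 2 stands at that same limit. Going by the values given here, no comparison of size between any two compounds is therefore possible, and no measured step exists.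

Compound 4 `c1ccc(-c2ccc(Cn3cncc3CNc3ccc(-c4nc5ccccc5s4)c(-c4ccccc4)c3)cc2)cc1` differs from compound 3 by phenyl in place of ethyl on an aromatic carbon. With nothing but limits to lean on, no step beyond the usual scatter is expected in this assay in either direction. Compound 4 is estimated at 10000 nM, with a range of 3000 nM to 30000 nM, most likely again reported only as a limit. The expected step is a step that the limit leaves unreadable from compound 3 to compound 4.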

Compound 4, half-maximal effective concentration: > 1000 nM
Compound 4 gave a limit, no number; the forecaster's own chance of this, stated with the estimate: 80%; the middle value is on the limit's open side.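

Compound 3 and compound 4 are both reported only as limits in this assay, so no step can be read between them. The compounds shown leave open whether phenyl in place of ethyl on an aromatic carbon changes the reading at all.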